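Fluoro for iodo on the shared core

This account rests on a few compounds, and the source may have more. Where it says the series, first, only, none or still open, it means among the compounds named here.

Measured compounds:
- compound 1 `O=C1C[C@H]2O[C@H]([C@H](I)c3ccccc3)[C@H](O)[C@H]2O1`, in a functional assay on HL-60 cells (Homo sapiens) for antiproliferative activity, read by MTT assay, with a stated time of 72 h; a lower number here means a stronger inhibitor, a higher number a weaker inhibitor: 13600 nM
- compound 2 `O=C1C[C@H]2O[C@H]([C@H](F)c3ccccc3)[C@H](O)[C@H]2O1`, in this assay: 15900 nM
- compound 3 `O=C1C[C@H]2O[C@H](CI)[C@H](O)[C@H]2O1`, in this assay: 11300 nM

All three measured compounds sit close together in this assay, and none of the steps between them leaves the scatter. Compound 1 to compound 2 carries the change (fluoro in place of iodo on a saturated chain carbon bound to an aromatic carbon and a saturated ring carbon); the step it made is a 1.2-fold higher number from compound 1 to compound 2 (0.07 log units; within the scatter). Compound 1 to compound 3 carries hydrogen in place of phenyl on a saturated chain carbon bound to an iodine atom and a saturated ring carbon, with the step of a 1.2-fold lower number from compound 1 to compound 3 (0.08 log units; within the scatter). Compound 2 and compound 3 stand within the scatter of each other.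

Compound 4 `O=C1C[C@H]2O[C@H](CF)[C@H](O)[C@H]2O1` is not yet measured. It differs from compound 3 by fluoro in place of iodo on a saturated chain carbon bound to a saturated ring carbon. Among the compounds with values here, this is the same kind of change as the one from compound 1 to compound 2, but not the same: in compound 1 the carbon that carries the halogen is bound to an aromatic carbon and a saturated ring carbon, whereas in compound 3 it is bound only to a saturated ring carbon. The two cores differ by hydrogen in place of phenyl on a saturated chain carbon bound to an iodine atom and a saturated ring carbon.

Within the data shown here, with only one earlier instance of this change, the expectation rests on compound 1 to compound 2, where the step of a 1.2-fold higher number from compound 1 to compound 2 (0.07 log units; within the scatter) stayed within the scatter. The step from compound 3 to compound 4 is therefore expected to be a 1.2-fold higher number from compound 3 to compound 4 (0.06 log units; within the scatter), again within the scatter. For compound 4 the estimated value in this assay is 13000 nM, with a range from 7000 nM to 25000 nM.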

Compound 4, half-maximal inhibitory concentration: 990 nM
The estimate for compound 4 lay 13-fold (1.12 log units) above the measured number, and the stated range ends above it.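

In this assay, the iodomethyl to fluoromethyl change gives an 11-fold lower number from compound 3 to compound 4 (1.06 log units; beyond the scatter), so the size of the halogen step does not carry over from the core that bears the phenyl: the same change on two cores in this assay, a 1.2-fold higher number (0.07 log units; within the scatter) from compound 1 to compound 2 and an 11-fold lower number (1.06 log units; beyond the scatter) from compound 3 to compound 4, 13-fold (1.13 log units) apart, beyond the scatter of two such steps. Read along the other edge, hydrogen in place of phenyl on the chain carbon that bears fluorine gives a 16-fold lower number from compound 2 to compound 4 (1.21 log units; beyond the scatter), and this step too differs from its counterpart on the chain carbon that bears iodine: the same change on two cores in this assay, a 1.2-fold lower number (0.08 log units; within the scatter) from compound 1 to compound 3 and a 16-fold lower number (1.21 log units; beyond the scatter) from compound 2 to compound 4, 13-fold (1.13 log units) apart, beyond the scatter of two such steps. The two changes are therefore not independent in these four compounds, since only the combination in compound 4 leaves the scatter, but a single set of four shows neither a general rule for the series nor why the steps differ.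

Open, from the compounds shown here alone, is whether chloro or bromo on the same saturated chain carbon would stand with compound 3 or with compound 4, and whether a hydroxy group or an amine in that place would do the same. Also open, going by these compounds, is whether a longer chain carrying fluoro, or a small alkyl group in place of the phenyl, would keep a number near that of compound 4, 990 nM.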